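The source may hold more compounds than are shown below. What is called first, only, known or untested is meant among the compounds shown, and "the series" means these compounds.

Measured compounds:
Compound 1, `CC(C)c1ccc2c(CCCS(=O)(=O)Nc3ccccc3)cc(C(=O)O)c-2cc1`: 12000 nM
Compound 2, `CC(C)c1ccc2c(CCCCCS(=O)(=O)Nc3ccccc3)cc(C(=O)O)c-2cc1`: 1500 nM
Compound 3, `CC(C)c1ccc2c(CCCS(=O)(=O)Nc3ccccc3)cc(S(=O)(=O)O)c-2cc1`: 8700 nM

All three were tested in a functional assay on thoracic aorta for antagonist activity at thromboxane A2 receptor (Rattus norvegicus); a higher number here means a weaker inhibitor, a lower number a stronger inhibitor. Compound 2 gives the lowest number of the three, and its gaps to compound 1 and to compound 3 both lie beyond the usual scatter, so it is the strongest inhibitor among the measured compounds. The structural difference between the core of compound 1 and the core of compound 2 is not broken down here.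

Compound 3 is obtained from compound 1 by one change, (sulfo in place of carboxy on an aromatic carbon). This change gave a 1.4-fold lower number from compound 1 to compound 3 (0.14 log units; within the scatter), a step that stays within the scatter.

Compound 4, `CC(C)c1ccc2c(CCCCCS(=O)(=O)Nc3ccccc3)cc(S(=O)(=O)O)c-2cc1`, has not yet been measured in this assay. It is obtained from compound 2 by the same change, (sulfo in place of carboxy on an aromatic carbon). Because the earlier instance gave a 1.4-fold lower number from compound 1 to compound 3 (0.14 log units; within the scatter), a step of about the same size, a 1.4-fold lower number from compound 2 to compound 4 (0.13 log units; within the scatter), is expected here. For compound 4 the expected value is therefore 1100 nM, estimated to fall between 400 nM and 3000 nM.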

Compound 4, half-maximal inhibitory concentration: 1400 nM
Estimate against measurement, compound 4: 1.3-fold (0.10 log units) below, and the stated range covers the measured number.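

Replacing carboxy with sulfo on the core of compound 2 behaves as it did on the core of compound 1 in this assay, with a 1.1-fold lower number from compound 2 to compound 4 (0.03 log units; within the scatter). The two instances agree in size: the same change on two cores in this assay, a 1.4-fold lower number (0.14 log units; within the scatter) from compound 1 to compound 3 and a 1.1-fold lower number (0.03 log units; within the scatter) from compound 2 to compound 4, 1.3-fold (0.11 log units) apart, within the scatter of two such steps. This shows that on these two cores the change moves the number by no more than repeat measurements would, so it can be carried from one core to the other without a detectable gain or loss; it does not show that the same would hold on any other core, and two instances say nothing about why the step is so small.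

The compounds shown leave open how a tetrazole or a primary amide would read in that same place in this assay, and whether the change would stay as small on a core with a longer chain. They also leave open whether the same small step would appear in a test on a different tissue or species.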